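The source may hold more compounds than are shown below. What is called first, only, known or untested is meant among the compounds shown, and "the series" means these compounds.

Measured so far in a functional assay on U-251 cells (Homo sapiens) for antiproliferative activity, read by MTT assay, with a stated time of 48 h; on this read-out higher numbers stand for weaker inhibition and lower numbers for stronger inhibition:
- Compound 1 `COc1cccc(-c2nc3cccc(-c4cc(OC)c(OC)c(OC)c4)c3o2)c1`: > 25000 nM, a limit
- Compound 2 `COc1ccc(-c2nc3cccc(-c4cc(OC)c(OC)c(OC)c4)c3o2)cc1F`: 1700 nM
- Compound 3 `COc1cc(-c2cccc3nc(-c4ccc(F)cc4)oc23)cc(OC)c1OC`: > 25000 nM, a limit

Compound 3 stands at a limit of this assay, > 25000 nM, and has no number. Most of the series rests on (the limit of > 25000 nM in this assay, at which 2 of the 3 values shown sit).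

Next is compound 4 `COc1cc(-c2cccc3nc(-c4cccc(Br)c4)oc23)cc(OC)c1OC`, with the change (3-bromophenyl in place of 4-fluorophenyl on an aromatic carbon). In words, 3-bromophenyl takes the place of 4-fluorophenyl on an aromatic carbon.

All three measured steps concern this same place. The step of an at least 14-fold higher number from compound 2 to compound 3 (1.16 log units; beyond the scatter) is large, and so is the step of an at least 14-fold lower number from compound 1 to compound 2 (1.16 log units; beyond the scatter), so a change here can matter. Going by the values given here, both depend on compound 2, the only compound with a number, and its 3-fluoro-4-methoxyphenyl group is absent from compound 4. The step that the two limits leave unreadable from compound 1 to compound 3 gives no size. The nearest comparison is compound 1, whose 3-methoxyphenyl group gives > 25000 nM, which is a limit.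

No clear step is therefore expected in this assay, and compound 4 may well report a limit again, with any movement expected toward a lower number. The expected step is an at least 1.2-fold lower number from compound 3 to compound 4 (0.09 log units; that floor lies within the scatter). For compound 4 the estimated value is 20000 nM, with an expected range of 5000 nM to 50000 nM.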

Compound 4, half-maximal inhibitory concentration: 6800 nM
The estimate for compound 4 lay 2.9-fold (0.47 log units) above the measured number, within the range that was stated.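

In this assay, going by these compounds alone, the position on the five-membered aromatic ring, next to the ring nitrogen and next to the ring oxygen, now gives a number with a second aryl group, so the 3-fluoro-4-methoxyphenyl group of compound 2 is not the only group that leaves the limit, with 3-bromophenyl in place of 4-fluorophenyl giving an at least 3.6-fold lower number from compound 3 to compound 4 (0.56 log units; beyond the scatter). Bromo in place of methoxy on this phenyl ring gives an at least 3.6-fold lower number from compound 1 to compound 4 (0.56 log units; beyond the scatter), while 3-bromophenyl in place of 3-fluoro-4-methoxyphenyl gives a 4.0-fold higher number from compound 2 to compound 4 (0.60 log units; beyond the scatter), so the 3-bromophenyl group does not match the number of compound 2. The steps from compound 3 and compound 1 are floors only, because both start from a limit: the limit of > 25000 nM in this assay, at which 2 of the 4 values shown sit.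

The phenyl groups shown carry only fluoro, bromo and methoxy, so whether an amine, a carboxylic acid or a nitrile on this ring would give a lower number stays open. Bromo and fluoro are not compared at one ring place, and the step between compound 1 and compound 3 cannot be read.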